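Swapping the dimethoxyphenyl for a thiophene on the shared core

A few compounds are considered here, and "the series" means these few. Any claim that something is new, unique, unknown or untested is made for them only; others in the source may bear on it.

Compound 1 `COc1ccc(-c2cc(N)c(C(=O)c3cc(OC)c(OC)c(OC)c3)s2)cc1OC` and compound 2 `COc1cccc(-c2cc(N)c(C(=O)c3cc(OC)c(OC)c(OC)c3)s2)c1` share one core and were both tested in a functional assay on CCRF-CEM cells (Homo sapiens) for antiproliferative activity; a higher number here means a weaker inhibitor, a lower number a stronger inhibitor. In this assay compound 1 gives 20 nM, and compound 2 gives 16 nM. Among the compounds with values here, compound 1 thus holds the highest of the two numbers, but the only measured step, a 1.3-fold lower number from compound 1 to compound 2 (0.10 log units; within the scatter), is within the scatter and amounts to hydrogen in place of methoxy on an aromatic carbon. Compound 3 `COc1cc(C(=O)c2sc(-c3cccs3)cc2N)cc(OC)c1OC` has not yet been measured in this assay. It differs from compound 1 as follows: thiophen-2-yl in place of 3,4-dimethoxyphenyl on an aromatic carbon. The step from compound 1 to compound 2 is the only one that bears on this change, and it was within the scatter. Replacing the whole ring is a larger change than anything measured so far, so the expected step of a 1.5-fold higher number from compound 1 to compound 3 (0.18 log units; within the scatter) is modest but carries wide uncertainty. Compound 3 is therefore estimated at 30 nM, with a range from 8 nM to 120 nM.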

Compound 3, half-maximal inhibitory concentration: 9.4 nM
Estimate against measurement, compound 3: 3.2-fold (0.50 log units) above; low and high end bracket the measured number.
By their numbers in this assay, from the lowest: compounds 3, 2 and 1 (each within the scatter of the next, the first and the last beyond it).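

At the position next to the ring sulfur, the whole 3,4-dimethoxyphenyl can give way to thiophen-2-yl, a five-membered aromatic ring, with a 2.1-fold lower number from compound 1 to compound 3 (0.33 log units; beyond the scatter) in this assay as a step beyond the scatter. Against the 3-methoxyphenyl, a 1.7-fold lower number from compound 2 to compound 3 (0.23 log units; within the scatter) stays within the scatter, so these two compounds cannot be told apart, and a six-membered aromatic ring of carbon only is not needed here for numbers of this size. Nothing shown accounts for either step.

Going by these compounds, what remains open is how furan-2-yl or thiophen-3-yl would read at this position, and so whether the sulfur of the entering ring counts. Also open, on these data alone, is whether an aromatic ring is needed here at all, which a cyclohexyl or a plain methyl group would test.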